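The compounds below may be only part of what the source reports. "The series", "measured", "known", "first", "only" and "open" are said of these compounds alone.

Among the compounds with values here, compound 2 `Cc1ccc(C)c(OCc2nnc(C(=O)Nc3ccc(CCC(=O)O)cc3)s2)c1` gives 1530 nM in a functional assay on CHO cells for agonist activity at Free fatty acid receptor 1 (Homo sapiens), read by FLIPR and calcium flux, tested at 1 uM (a lower number here means that less compound is needed, a higher number that more compound is needed for the effect), the lower of the two numbers known so far, while compound 1 `O=C(O)CCc1ccc(NC(=O)c2nnc(COc3ccc(F)cc3)s2)cc1` gives 5390 nM. Within the data shown here, the one measured step, a 3.5-fold lower number from compound 1 to compound 2 (0.55 log units; beyond the scatter), replaced the group attached to the oxygen on a saturated carbon. Compound 3 `O=C(O)CCc1ccc(NC(=O)c2nnc(COc3ccc4c(c3)CCC4)s2)cc1` alters that same group once more: 2,3-dihydro-1H-inden-5-yl in place of 2,5-dimethylphenyl on an oxygen on a saturated carbon. Among the measured compounds shown here, because the only comparison available is a 3.5-fold lower number from compound 1 to compound 2 (0.55 log units; beyond the scatter), which concerns a different pair of groups at the same place, it shows only that this position tolerates a swap and can shift the number modestly; it offers no direct guide for a fused two-ring group. The step of a 1.3-fold lower number from compound 2 to compound 3 (0.11 log units; within the scatter) is therefore expected to be small, close to the scatter, leaning toward a lower number. For compound 3 the estimate is 1200 nM, with a range from 400 nM to 4000 nM.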

Compound 3, half-maximal effective concentration: 1380 nM
Compound 3: the middle estimate sits 1.2-fold (0.06 log units) below what was measured; measured number inside the range.
By their numbers in this assay, from the lowest: compounds 3 and 2 (each within the scatter of the next); then compound 1.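

In this assay, a 1.1-fold lower number from compound 2 to compound 3 (0.04 log units; within the scatter), so the fused 2,3-dihydro-1H-inden-5-yl group and the 2,5-dimethylphenyl group cannot be told apart at this position on the oxygen. Compared with the 4-fluorophenyl group, a 3.9-fold lower number from compound 1 to compound 3 (0.59 log units; beyond the scatter), which gives a second replacement, now with a five-membered non-aromatic ring added to the six-membered aromatic ring, that ends up with a lower number than compound 1. Nothing available explains why these groups give these numbers.

The compounds shown leave open whether this position needs an aromatic ring of carbon only, since a cyclohexyl group or a pyridine ring here would test that. They also leave open whether a plain unsubstituted phenyl group would sit with compound 1 or with compound 2 and compound 3.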